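This account rests on a few compounds, and the source may have more. Where it says the series, first, only, none or still open, it means among the compounds named here.

Working notes on the series. In an assay on isolated protein for inhibition of leukotriene B4 receptor 1 (Homo sapiens), tested at 10 uM (a higher number here means more inhibition at the concentration tested (going by the name of the read-out), a lower number less inhibition), compound 2 `C=CCc1cc(C(C)=O)c(O)cc1OCCCCCCCCC#N` gives 86%, the lowest of the two numbers measured; compound 1 `C=CCc1cc(C(C)=O)c(O)cc1OCCCCCCC#N` gives 97%. Going by the values given here, the one measured step, a number 11 percentage points lower from compound 1 to compound 2 (beyond the scatter), concerns the far end of the same chain and is modest in size. Compound 3 `C=CCc1cc(C(C)=O)c(O)cc1OCCCCCCC` differs from compound 2 by hydrogen in place of cyanomethyl on a saturated chain carbon, seven bonds along the chain from an oxygen on an aromatic ring. Among the compounds with values here, no measured step covers loss of the nitrile, so the expectation rests on that single modest step: compound 3 is expected to move by a number 14 percentage points lower from compound 2 to compound 3 (beyond the scatter), a loss of similar order. Compound 3 is estimated at 72%, with a range from 45% to 92%.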

Compound 3, a percentage reported as inhibition, at one concentration (the size of the read-out at that concentration, not a potency): 31%
The estimate for compound 3 lay 41 percentage points above the measured number, and the stated range ends above it.
By their numbers in this assay, from the lowest: compound 3; then compound 2; then compound 1.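

The change to hydrogen in place of cyanomethyl gives a number 55 percentage points lower from compound 2 to compound 3 (beyond the scatter) in this assay and methyl in place of cyano gives a number 66 percentage points lower from compound 1 to compound 3 (beyond the scatter) on the same read-out. Both steps are large, whereas the change in chain length between the two nitriles was only modest, so the far end of this chain matters much more than that first step showed. Nothing available bears on the reason for this loss.

Going by these compounds, whether the nitrile itself is needed or other chain-end groups would serve remains open. A carboxylic acid or an amine at the chain end could separate these possibilities.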